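A few compounds are considered here, and "the series" means these few. Any claim that something is new, unique, unknown or untested is made for them only; others in the source may bear on it.

Metabolic stability in the series so far. In an ADME assay on microsomes from liver (Homo sapiens) for metabolic stability, read by LC-MS, using NADPH, with a stated time of 10 min, tested at 10 uM (a lower number here means that the compound disappears faster, a higher number that the compound lasts longer), compound 1 `Nc1ncnc2c1c(Oc1cccc(C(F)(F)F)c1)nn2[C@H]1C[C@H](O)C1` gives 1.25 h. Compound 2 `Nc1ncnc2c1c(Oc1cc(C(F)(F)F)ccn1)nn2[C@H]1CC[C@@H](N)CC1` returns only a limit of the measurement, > 2.41 h, not a number. Compound 3 `N#Cc1ccnc(Oc2nn([C@H]3C[C@H](O)C3)c3ncnc(N)c23)c1` likewise sits at a limit in this assay, > 2.41 h. With the limit of > 2.41 h in this assay, at which 2 of the 3 values shown sit, compound 2 stands among the compounds that outlast the window, and no finite half-life is known for it. For the measured compounds named here, no pair of measured compounds differs in a single place, so no measured step is available. Compound 4 `Nc1ncnc2c1c(Oc1cc(C(F)(F)F)ccn1)nn2CC1CC1` differs from compound 2 by cyclopropylmethyl in place of 4-aminocyclohexyl on an aromatic nitrogen. For this change the expected step in this assay is an at least 1.6-fold lower number from compound 2 to compound 4 (0.20 log units; that floor lies within the scatter), a move toward shorter half-life that may or may not exceed the scatter. Compound 4 is therefore estimated at 1.5 h, within 0.6 h to 2.8 h.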

Compound 4, half-life: 1.87 h
For compound 4 the middle estimate is 1.2-fold (0.10 log units) below the measured one; the range from low to high includes it.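

At this position on the aromatic nitrogen, cyclopropylmethyl in place of 4-aminocyclohexyl gives a finite half-life in this assay, and the change reads as an at least 1.2-fold lower number from compound 2 to compound 4 (0.11 log units; that floor lies within the scatter). This is the only reading so far for a change at this position, and it is only a floor, so the full size of the step stays unknown because compound 2 gives no finite number: the limit of > 2.41 h in this assay, at which 2 of the 4 values shown sit.

On these data alone, whether a plain cyclohexyl without the amine, or a longer alkyl chain, on this nitrogen would behave like compound 2 or like compound 4 remains open.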